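Hydroxy to Methoxy: From Compound 1 to Compound 3

A few compounds are considered here, and "the series" means these few. Any claim that something is new, unique, unknown or untested is made for them only; others in the source may bear on it.

In a functional assay on A549 cells (Homo sapiens) for antiproliferative activity, read by sulforhodamine B assay, with a stated time of 48 h (a higher number here means a weaker inhibitor of growth, a lower number a stronger inhibitor of growth), compound 1 (`O=C(NCCCNc1cc(-c2cn(-c3ccccc3)nc2-c2cccc(O)c2)ccn1)Nc1ccc(F)cc1`) gives > 21700 nM, which is a limit of the assay and not a number. Compound 2 (`O=C(NCCCNc1cc(-c2cn(-c3ccccc3)nc2-c2cccc(O)c2)ccn1)Nc1cccc(C(F)(F)F)c1`) gives 11200 nM. Compound 3 (`COc1cccc(-c2nn(-c3ccccc3)cc2-c2ccnc(NCCCNC(=O)Nc3ccc(F)cc3)c2)c1`) turns the hydroxy of compound 1 into methoxy, with methyl in place of hydrogen on an oxygen on an aromatic ring. For the measured compounds named here, the only measured step, an at least 1.9-fold lower number from compound 1 to compound 2 (0.28 log units; that floor lies within the scatter), changes a different group, so it gives no size for this change. No step beyond the scatter is therefore expected, and the estimated change is an at least 1.0-fold lower number from compound 1 to compound 3 (0.03 log units; that floor lies within the scatter). Compound 3 is expected at about 20000 nM, within an estimated range of 9000 nM to 45000 nM.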

Compound 3, concentration for total growth inhibition: > 37000 nM
Compound 3: a limit, no number; the forecaster's own chance of this, stated with the estimate: 50%; middle value at least 1.8-fold (0.26 log units) from the limit.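

Compound 1 and compound 3 each give only a limit of the assay, not a number, and no step can be read between them. The compounds shown leave open whether hydroxy to methoxy changes the result in this assay at all.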